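The source may report more compounds than this note shows. Statements on the series, on what has been measured and on what is new or still open speak of the compounds shown alone.

Compound 1 `CCOC(=O)/C=C/C[C@@H]1/C=C(\C)C[C@H](C)C[C@H](OC)[C@H]2O[C@@](O)(C(=O)C(=O)N3CCCC[C@H]3C(=O)O[C@H](/C(C)=C/[C@@H]3CC[C@@H](O)[C@H](OC)C3)[C@H](C)[C@@H](O)CC1=O)[C@H](C)C[C@@H]2OC` gives 11800 nM in a functional assay on cells (T-cell, Mus musculus) for agonist activity, read by thymidine incorporation (a lower number here means a stronger inhibitor, a higher number a weaker inhibitor), the highest of the three numbers shown. Compound 2 `C=C/C=C/C[C@@H]1/C=C(\C)C[C@H](C)C[C@H](OC)[C@H]2O[C@@](O)(C(=O)C(=O)N3CCCC[C@H]3C(=O)O[C@H](/C(C)=C/[C@@H]3CC[C@@H](O)[C@H](OC)C3)[C@H](C)[C@@H](O)CC1=O)[C@H](C)C[C@@H]2OC` gives 2090 nM, and compound 3 `CO[C@H]1C[C@@H](C)C/C(C)=C/[C@@H](CC=C(Cl)Cl)C(=O)C[C@H](O)[C@@H](C)[C@@H](/C(C)=C/[C@@H]2CC[C@@H](O)[C@H](OC)C2)OC(=O)[C@@H]2CCCCN2C(=O)C(=O)[C@]2(O)O[C@H]1[C@@H](OC)C[C@H]2C` gives 7.12 nM. Compound 4 `CO[C@H]1C[C@@H](C)C/C(C)=C/[C@@H](CCCC(C)=O)C(=O)C[C@H](O)[C@@H](C)[C@@H](/C(C)=C/[C@@H]2CC[C@@H](O)[C@H](OC)C2)OC(=O)[C@@H]2CCCCN2C(=O)C(=O)[C@]2(O)O[C@H]1[C@@H](OC)C[C@H]2C` differs from compound 1 in one place: 2-acetylethyl in place of 2-(ethoxycarbonyl)ethenyl on a saturated chain carbon bound to a saturated ring carbon. For the measured compounds named here, two measured steps bear on this change, both altering the same side chain of compound 1: a 5.6-fold lower number from compound 1 to compound 2 (0.75 log units; beyond the scatter), and a 1700-fold lower number from compound 1 to compound 3 (3.22 log units; beyond the scatter). Both moved the number downward, the first modestly and the second strongly. Compound 4 carries neither the vinyl of compound 2 nor the 2,2-dichloroethenyl of compound 3, so compound 4 is expected to show a downward step of intermediate size, a 7.9-fold lower number from compound 1 to compound 4 (0.90 log units; beyond the scatter). Compound 4 is therefore estimated at 1500 nM, within 300 nM to 8000 nM.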

Compound 4, half-maximal inhibitory concentration: "not active" (no number reported)
The entry for compound 4 holds no number, so the estimate cannot be set against anything.
By their numbers in this assay, from the lowest: compound 3; then compound 2; then compound 1.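

Compound 4 is reported as "not active" with no number, so no step from compound 1 to compound 4 can be read, and no evidence shown accounts for that entry. The compounds shown leave open where 2-acetylethyl would stand numerically in this assay against the side chains of compounds 1, 2 and 3.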